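Working notes: replacing nitro with amino on compound 2

The compounds below may be only part of what the source reports. "The series", "measured", "known", "first", "only" and "open" are said of these compounds alone.

compound 1 `COC1=CC(=O)c2c(c(COc3cccc([N+](=O)[O-])c3)c(C)n2C)C1=O` – 258 nM
compound 2 `COC1=CC(=O)c2c(COc3ccc([N+](=O)[O-])cc3)c(C)n(C)c2C1=O` – 355 nM

Both compounds were measured in a functional assay on MIA PaCa-2 cells (Homo sapiens) for cytotoxicity, read by MTT assay, with a stated time of 72 h; a lower number here means a stronger inhibitor, a higher number a weaker inhibitor. In this assay compound 2 gives 355 nM, which lies within the scatter of compound 1 at 258 nM. Among the compounds with values here, the two values therefore set no order, and compound 2 stands level with the only other measured compound.

The next compound is compound 3 `COC1=CC(=O)c2c(COc3ccc(N)cc3)c(C)n(C)c2C1=O`, which is compound 2 with one change: amino in place of nitro on an aromatic carbon. This places amino in place of nitro on an aromatic carbon, para to a large group.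

Within the data shown here, both measured compounds carry a nitro group, so no measured pair shows what this replacement does in this assay. The expectation is therefore loose and the range wide. A moderate move toward a weaker inhibitor is expected, with an estimated step of a 2.3-fold higher number from compound 2 to compound 3 (0.35 log units; beyond the scatter), although a result within the scatter would not be surprising. For compound 3 the estimated value is 800 nM, with an expected range of 220 nM to 3500 nM.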

Compound 3, half-maximal inhibitory concentration: 160 nM
Compound 3: middle estimate off by 5.0-fold (0.70 log units), on the high side, outside the stated range (below it).
By their numbers in this assay, from the lowest: compounds 3, 1 and 2 (each within the scatter of the next, the first and the last beyond it).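

In this assay, amino in place of nitro on an aromatic carbon, para to a large group, gives a 2.2-fold lower number from compound 2 to compound 3 (0.35 log units; beyond the scatter). Nitro is therefore not required at this position for activity in these cells, and amino is accepted there with a modest gain, which compound 1 and compound 2 could not show as both carry nitro. No measurement of any property of these compounds accompanies the step, so the data offer no explanation for it.

A single replacement at this position leaves open whether the gain is specific to amino or would also appear with other groups there, such as a hydroxyl, a methoxy, an acetamide or a dimethylamino group. As far as these compounds go, it is also open whether replacing the nitro group of compound 1 with amino would produce a step of similar size and direction, so the result cannot yet be extended beyond this one pair of compounds.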